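Three Analogues at the Limit, a Fourth Awaited

The compounds below may be only part of what the source reports. "The series", "measured", "known", "first", "only" and "open" are said of these compounds alone.

In a functional assay on A549 cells (Homo sapiens) for antiproliferative activity, read by MTT assay, with a stated time of 48 h (a lower number here means a stronger inhibitor, a higher number a weaker inhibitor), three compounds of the shared core have been measured so far:

Compound 1 `N#CC1=C(N)Oc2c(c3nc4ccccc4nc3c3ccccc23)C12C(=O)N(Cc1cnnn1-c1ccc(F)cc1)c1ccccc12` gives > 50000 nM, a limit of the assay.
Compound 2 `COc1ccc(-n2nncc2CN2C(=O)C3(C(C#N)=C(N)Oc4c3c3nc5ccccc5nc3c3ccccc43)c3ccccc32)cc1` gives > 50000 nM, also a limit.
Compound 3 `COc1ccccc1-n1nncc1CN1C(=O)C2(C(C#N)=C(N)Oc3c2c2nc4ccccc4nc2c2ccccc32)c2ccccc21` gives > 50000 nM, again a limit.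

Compound 1 therefore stands at the limit rather than at a number, and the limit of > 50000 nM in this assay, at which 3 of the 3 values shown sit, shows that none of the three values is readable. The step from compound 1 to compound 2, methoxy in place of fluoro on an aromatic carbon, reads a step that the two limits leave unreadable from compound 1 to compound 2; the step from compound 1 to compound 3 reads a step that the two limits leave unreadable from compound 1 to compound 3; and the step from compound 2 to compound 3 reads a step that the two limits leave unreadable from compound 2 to compound 3.

Compound 4 `CC(=O)Nc1ccc(-n2nncc2CN2C(=O)C3(C(C#N)=C(N)Oc4c3c3nc5ccccc5nc3c3ccccc43)c3ccccc32)cc1` is not yet measured. Compared with compound 1 the change is acetamido in place of fluoro on an aromatic carbon. For the measured compounds named here, the only step touching the same aromatic carbon is the one from compound 1 to compound 2, and it is unreadable, so no size or direction can be drawn from it. Going by the values given here, with every value so far at the limit, compound 4 is expected to sit there too, an expected step that the limit leaves unreadable from compound 1 to compound 4. The estimate for compound 4 in this assay is 80000 nM, within 35000 nM to 250000 nM.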

Compound 4, half-maximal inhibitory concentration: > 50000 nM
Compound 4: only a limit was reported; the forecaster's own chance of this, stated with the estimate: 85%; the middle value does not contradict the limit.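

In this assay compound 4 gives > 50000 nM as a limit and not a number. For the compounds shown here, its steps from compound 1, compound 2 and compound 3 therefore cannot be read, so no new step follows. The compounds shown leave open whether any group at this place on the phenyl ring, or any other change to the shared core, gives a readable value.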